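A few compounds are considered here, and "the series" means these few. Any claim that something is new, unique, unknown or untested is made for them only; others in the source may bear on it.

Compound 1, `CN(C)CCn1cnnc1-c1cc(Oc2ccc(NC(=O)N/N=C/c3c[nH]c4ccccc34)cc2F)ccn1`, gives 1300 nM in a functional assay on HT-29 cells (Homo sapiens) for cytotoxicity, read by MTT assay, with a stated time of 72 h; on this read-out higher numbers stand for weaker inhibition and lower numbers for stronger inhibition.
Compound 2, `COc1ccc(/C=N/NC(=O)Nc2ccc(Oc3ccnc(-c4nncn4CCN(C)C)c3)c(F)c2)c(OC)c1`, gives 1780 nM in this assay.

For the measured compounds named here, compound 2 carries the higher of these two numbers, but its only neighbour is close: the step of a 1.4-fold higher number from compound 1 to compound 2 (0.14 log units; within the scatter) stays within the scatter of repeated measurements, so the two compounds cannot be told apart on this read-out. That step swapped the aromatic group on the carbon that is double-bonded to nitrogen, putting 2,4-dimethoxyphenyl in place of 1H-indol-3-yl.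

Compound 3, `CN(C)CCn1cnnc1-c1cc(Oc2ccc(NC(=O)N/N=C/c3ccc(O)c(F)c3)cc2F)ccn1`, has not yet been measured. It differs from compound 2 as follows: 3-fluoro-4-hydroxyphenyl in place of 2,4-dimethoxyphenyl on a carbon with a double bond to nitrogen. Going by the values given here, the one measured step that bears on this, a 1.4-fold higher number from compound 1 to compound 2 (0.14 log units; within the scatter), also exchanged the ring on that same carbon and moved the number only within the scatter. On that basis the expected step of a 1.2-fold lower number from compound 2 to compound 3 (0.07 log units; within the scatter) is none beyond the scatter. Compound 3 is therefore estimated at 1500 nM, with a likely range from 600 nM to 4000 nM.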

Compound 3, half-maximal inhibitory concentration: 3310 nM
For compound 3 the middle estimate is 2.2-fold (0.34 log units) below the measured one; measured number inside the range.
By their numbers in this assay, from the lowest: compounds 1, 2 and 3 (each within the scatter of the next, the first and the last beyond it).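

For the compounds shown here, replacing 1H-indol-3-yl with 3-fluoro-4-hydroxyphenyl gives a 2.5-fold higher number from compound 1 to compound 3 (0.41 log units; beyond the scatter) and is the first change at this position to pass beyond the scatter, which shows that the ring on this carbon can shift the number, if only modestly. Against 2,4-dimethoxyphenyl, the same ring gives a 1.9-fold higher number from compound 2 to compound 3 (0.27 log units; within the scatter) and cannot be told apart, even though it brings a hydrogen-bond donor in place of a group with none. No measurement is available to explain either step.

Going by these compounds, all three compounds carry an aromatic ring on this carbon, so it remains open how a saturated group such as cyclohexyl, or a chain ending in an amine or a carboxylic acid, would read here. It is also open what the fluorine and the hydroxy group each contribute, since a phenyl ring bearing only one of them is not among these compounds.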